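Three Limits, One Unmeasured Neighbour

The compounds below may be only part of what the source reports. "The series", "measured", "known", "first", "only" and "open" are said of these compounds alone.

Compound 1 `Cc1cc(C)c(S(=O)(=O)N2CCC(C3OCC(C)CO3)CC2)c(C)c1` in an ADME assay on HCT-116 cells (Homo sapiens) for cytotoxicity, read by CellTiter-Glo, with a stated time of 72 h; on this read-out higher numbers stand for weaker inhibition and lower numbers for stronger inhibition: > 5000 nM
Compound 2 `Cc1cc(C)cc(-c2cccc(S(=O)(=O)N3CCC(N4CCC(C)CC4)CC3)c2)c1`: > 5000 nM
Compound 3 `Cc1cc(C)c(S(=O)(=O)N2CCC(N3CCC(C)OC3)CC2)c(C)c1`: > 5000 nM

Every one of these three readings is a limit of the assay, not a number. Compound 3 stands only at such a limit in this assay, and the other two compounds stand at a limit as well. Going by the values given here, the single change between measured compounds, a step that the two limits leave unreadable from compound 1 to compound 3, is therefore not readable in size or direction, because of the limit of > 5000 nM in this assay, at which 3 of the 3 values shown sit.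

Compound 4 `Cc1cc(C)c(S(=O)(=O)N2CCC(N3CC(C)CC(C)C3)CC2)c(C)c1` has not yet been measured. Compared with compound 3 it carries a group of 8 heavy atoms (7 carbon, 1 nitrogen; one six-membered non-aromatic ring with 1 hetero atom) in place of a group of 7 heavy atoms (5 carbon, 1 nitrogen, 1 oxygen; one six-membered non-aromatic ring with 2 hetero atoms), on a saturated ring carbon. Among the compounds with values here, no measured step bears on this change with a readable size; the only neighbouring step is itself hidden by the limit. Nothing in the shown data points to inhibition strong enough to fall below the limit, so compound 4 is expected to sit at or near the same limit, with an estimated step that the limit leaves unreadable from compound 3 to compound 4 that is not beyond the scatter. The estimate for compound 4 in this assay is 8000 nM, in a range from 3000 nM to 20000 nM.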

Compound 4, half-maximal inhibitory concentration: > 5000 nM
Compound 4 gave a limit, no number; the forecaster's own chance of this, stated with the estimate: 85%; the middle value does not contradict the limit.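

No step to compound 4 from compound 1 or compound 3 can be read in this assay, because these readings are limits, not numbers: the limit of > 5000 nM in this assay, at which 4 of the 4 values shown sit.

The compounds shown leave open how strongly any of them inhibits these cells, and which change, if any, would give a readable number.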